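A Ring Nitrogen Enters the Benzyl Group

This account rests on a few compounds, and the source may have more. Where it says the series, first, only, none or still open, it means among the compounds named here.

Three compounds share one core and differ only in the group on the nitrogen on the aromatic ring. Compound 1 `CC(C(=O)NCc1ccc(C(F)(F)F)nc1NC1CCCCC1)c1ccc(NS(C)(=O)=O)c(F)c1` gives 20.4 nM in a functional assay on CHO-K1 cells for antagonist activity at transient receptor potential cation channel subfamily V member 1 (Homo sapiens), read by FLIPR (a lower number here means a stronger inhibitor, a higher number a weaker inhibitor), compound 2 `CC1CCC(Nc2nc(C(F)(F)F)ccc2CNC(=O)C(C)c2ccc(NS(C)(=O)=O)c(F)c2)CC1` gives 27.2 nM, and compound 3 `CC(C(=O)NCc1ccc(C(F)(F)F)nc1NCc1ccccc1)c1ccc(NS(C)(=O)=O)c(F)c1` gives 15.8 nM. Compound 3 carries the lowest of the three numbers, but it is within the scatter of both others: the change from compound 1 to compound 3 was a 1.3-fold lower number from compound 1 to compound 3 (0.11 log units; within the scatter), and that from compound 2 to compound 3 was a 1.7-fold lower number from compound 2 to compound 3 (0.24 log units; within the scatter). The step from compound 1 to compound 2, a 1.3-fold higher number from compound 1 to compound 2 (0.12 log units; within the scatter), likewise stayed within the scatter.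

Compound 4 `CC(C(=O)NCc1ccc(C(F)(F)F)nc1NCc1cccnc1)c1ccc(NS(C)(=O)=O)c(F)c1` continues from compound 3 with one change, (pyridin-3-yl in place of phenyl on a saturated chain carbon bound to a nitrogen on an aromatic ring). Within the data shown here, no measured step exchanges phenyl for pyridin-3-yl, so none bears on it directly; the three steps show only that varied groups at this nitrogen give numbers within the scatter of one another. The author therefore expects no step beyond the scatter, an estimated 1.1-fold higher number from compound 3 to compound 4 (0.06 log units; within the scatter). Compound 4 is estimated at 18 nM, in a range from 7 nM to 50 nM.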

Compound 4, inhibition constant: "not active" (no number reported)
Compound 4 has no reported number here, so the estimate cannot be set against anything.
By their numbers in this assay, from the lowest: compounds 3, 1 and 2 (each within the scatter of the next).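

In this assay compound 4 is reported as "not active" without a number, so no step from compound 3 to compound 4 can be read, and nothing shown bears on this result. The compounds shown leave open how (pyridin-3-yl)methyl compares numerically with benzyl at this nitrogen.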